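Fluoro to methoxy, repeated on a second fluorophenyl

A few compounds are considered here, and "the series" means these few. Any claim that something is new, unique, unknown or untested is made for them only; others in the source may bear on it.

Compound 1 `O=[N+]([O-])c1ccc(CN2CCC(n3cc(CC(OCc4cc(-c5cccc(F)c5)no4)c4ccc(Br)cc4)nn3)CC2)cc1` gives 5000 nM in a functional assay on MDA-MB-231 cells (Homo sapiens) for cytotoxicity, with a stated time of 48 h; a higher number here means a weaker inhibitor, a lower number a stronger inhibitor. Compound 3 `O=[N+]([O-])c1ccc(CN2CCC(n3cc(CC(OCc4cc(-c5ccccc5F)no4)c4ccc(Br)cc4)nn3)CC2)cc1` gives 4000 nM in this assay. Compound 2 `COc1cccc(-c2cc(COC(Cc3cn(C4CCN(Cc5ccc([N+](=O)[O-])cc5)CC4)nn3)c3ccc(Br)cc3)on2)c1` reaches only a limit of this assay, > 25000 nM, so no number is known for it. The two cores differ as 2-fluorophenyl in place of 3-fluorophenyl on an aromatic carbon, and the step of a 1.3-fold lower number from compound 1 to compound 3 (0.10 log units; within the scatter) leaves compounds 1 and 3 indistinguishable. The change methoxy in place of fluoro on an aromatic carbon produces the step of an at least 5.0-fold higher number from compound 1 to compound 2 (0.69 log units; beyond the scatter); the step of an at least 6.2-fold lower number from compound 2 to compound 3 (0.79 log units; beyond the scatter) likewise puts compound 3 at a lower number than compound 2, which sits at the limit of > 25000 nM in this assay, at which 1 of the 3 values shown sits.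

Compound 4 `COc1ccccc1-c1cc(COC(Cc2cn(C3CCN(Cc4ccc([N+](=O)[O-])cc4)CC3)nn2)c2ccc(Br)cc2)on1` differs from compound 3 by methoxy in place of fluoro on an aromatic carbon. This is the same kind of change as from compound 1 to compound 2, but the place differs: in compound 2 the methoxy sits meta to a large group, in compound 4 ortho to a large group. Resting on the step of an at least 5.0-fold higher number from compound 1 to compound 2 (0.69 log units; beyond the scatter) seen from compound 1, the step from compound 3 to compound 4 is expected to be a 6.3-fold higher number from compound 3 to compound 4 (0.80 log units; beyond the scatter). Compound 4 is estimated at 25000 nM, between 8000 nM and 80000 nM, and may again return only a limit.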

Compound 4, half-maximal inhibitory concentration: > 25000 nM
Compound 4 gave a limit, no number (the forecaster's own chance of this, stated with the estimate: 55%); the middle value sits exactly at the limit.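

In this assay compound 4 returns only a limit, > 25000 nM, not a number. Methoxy in place of fluoro gives an at least 6.2-fold higher number from compound 3 to compound 4 (0.79 log units; beyond the scatter), and 2-methoxyphenyl in place of 3-fluorophenyl gives an at least 5.0-fold higher number from compound 1 to compound 4 (0.69 log units; beyond the scatter). The change therefore moves to a higher number on both cores shown, beyond the scatter each time, but with each size bounded on one side only, these compounds do not show whether it carries over with the same size: the same change on two cores in this assay, an at least 5.0-fold higher number (0.69 log units; beyond the scatter) from compound 1 to compound 2 and an at least 6.2-fold higher number (0.79 log units; beyond the scatter) from compound 3 to compound 4; the limit leaves it open whether they differ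

From the compounds shown here alone, the step between the two methoxy compounds cannot be read, so any difference between 2-methoxyphenyl and 3-methoxyphenyl stays hidden: the limit of > 25000 nM in this assay, at which 2 of the 4 values shown sit. Also open is how a hydroxyl, a methyl or an amine in place of the fluoro would read in this assay, and whether any such group would give a measurable number rather than another limit.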